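The compounds below may be only part of what the source reports. "The series", "measured", "known", "first", "only" and "open" are said of these compounds alone.

Compound 2, whose structure is `CCNC(=O)N1CCN(C(=S)SCc2cn(Cc3ccc(OC)cc3)nn2)CC1`, stands at the edge of what the test can report. In a functional assay on MGC-803 cells (Homo sapiens) for cytotoxicity, read by MTT assay, with a stated time of 72 h (a higher number here means a weaker inhibitor, a lower number a stronger inhibitor), compound 2 gives > 128000 nM, which is a limit of the assay and not a measured number. The closely related compound 1, with the structure `COc1ccc(Cn2cc(CSC(=S)N3CCN(C(N)=O)CC3)nn2)cc1`, is in the same position. In this assay compound 1 gives > 128000 nM, again a limit rather than a number. The step between them, a step that the two limits leave unreadable from compound 1 to compound 2, puts ethyl in place of hydrogen on an amide-type nitrogen, and its size cannot be read because of the limit of > 128000 nM in this assay, at which 2 of the 2 values shown sit.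

Compound 3, with the structure `CCN(C)C(=O)N1CCN(C(=S)SCc2cn(Cc3ccc(OC)cc3)nn2)CC1`, continues along the same nitrogen: methyl in place of hydrogen on an amide-type nitrogen. Going by the values given here, the only measured step that bears on this change is the unreadable one from the ethyl substitution, so no size and no direction can be drawn from it in this assay. The most that can be said is that both neighbours sit at the limit, which gives no sign of a reading below it. Compound 3 is therefore expected to give about 160000 nM, within a range from 60000 nM to 450000 nM. The step this estimate implies, a step that the limit leaves unreadable from compound 2 to compound 3, is expected to lie within the scatter.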

Compound 3, half-maximal inhibitory concentration: 87900 nM
The estimate for compound 3 lay 1.8-fold (0.26 log units) above the measured number; the measured number falls inside the stated range.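

In this assay, going by these compounds alone, compound 3 gives 87900 nM, the first actual reading in this set, so a nitrogen carrying both ethyl and methyl brings the series within the range the test can report. Methyl in place of hydrogen on this amide-type nitrogen gives an at least 1.4-fold lower number from compound 2 to compound 3 (0.16 log units; that floor lies within the scatter), and the wider change of ethyl(methyl)amino in place of amino on the carbonyl carbon gives an at least 1.4-fold lower number from compound 1 to compound 3 (0.16 log units; that floor lies within the scatter); each of these is only a floor, so the true gap could be larger, but as printed neither step yet establishes a real gain. The earlier pair offered no number to measure from, and the reference point for both steps is still not a measured value: the limit of > 128000 nM in this assay, at which 2 of the 3 values shown sit.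

The compounds shown leave open whether a longer chain such as propyl or butyl in place of the methyl would lower the number further, or whether the gain, if real, needs ethyl at all. Dimethylamino or a piperidine ring on the carbonyl carbon would test how much of the reading depends on this particular pair of groups.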